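Hydroxy for methyl on the ketone-bearing ring of a diether acid series

The compounds below may be only part of what the source reports. "The series", "measured", "known", "first", "only" and "open" are said of these compounds alone.

Working notes on a short set of linked diaryl diethers. Compound 1 `Cc1cc(C(=O)O)ccc1OCCCCOc1ccc(C(=O)CC(C)C)c(O)c1C` carries a hydroxy group and in an assay on HEK293 cells for positive allosteric modulation of metabotropic glutamate receptor 2 (Rattus norvegicus), read by thallium flux, with a stated time of 2.5 min (on this read-out higher numbers stand for an effect only at larger amounts of compound and lower numbers for an effect already at smaller amounts), compound 1 gives 192 nM. Compound 2 `Cc1c(OCCCCOc2ccc(C(=O)O)cc2)ccc(C(=O)CC(C)C)c1C` is the all-methyl counterpart; in this assay compound 2 gives "not determined" (no result reported), so compound 2 stands without a single number and offers no anchor of its own. Compound 3 `Cc1c(OCCCCOc2ccc(C(=O)O)cc2)ccc(C(=O)CC(C)C)c1O` is the target of the next step. Relative to compound 2 the change is hydroxy in place of methyl on an aromatic carbon. With no value for compound 2, the size and direction of this step cannot be stated from the pair itself; any expectation for compound 3 rests on compound 1 alone. Compound 3 is expected to fall in the same region as compound 1 because compound 1 gives 192 nM in this assay and also carries a hydroxy group. The estimate for compound 3 is 300 nM, with a range from 80 nM to 1500 nM.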

Compound 3, half-maximal effective concentration: 122 nM
For compound 3 the middle estimate is 2.5-fold (0.39 log units) above the measured one; the measured number falls inside the stated range.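

The step from compound 2 to compound 3 cannot be read in this assay, so hydroxy in place of methyl on this aromatic carbon still has neither size nor direction. What the result adds concerns a different place: with the hydroxy kept, the loss of a methyl group elsewhere in the molecule gives a 1.6-fold lower number from compound 1 to compound 3 (0.20 log units; within the scatter), so the two hydroxy compounds cannot be told apart and that methyl shows no measurable contribution in this pair. No measurement shown here offers an explanation for this.

As far as these compounds go, whether the hydroxy itself matters stays open until a compound with a number lacks it. A methoxy group or an amine on the same aromatic carbon, or a longer chain between the two ether oxygens, would test how much of the shared core can change.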